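A few compounds are considered here, and "the series" means these few. Any claim that something is new, unique, unknown or untested is made for them only; others in the source may bear on it.

Among the measured compounds shown here, compound 2 `CCC(O)C1=CC(=O)c2c(OC)ccc(OC)c2C1=O` gives the highest of the three numbers measured so far in a functional assay on L1210 cells (Mus musculus) for cytotoxicity (a higher number here means that more compound is needed for the effect, a lower number that less compound is needed), namely 0.516 ug/mL. Compound 1 `COc1cc(C(C)O)c(OC)c2c1C(=O)C=CC2=O` gives 0.132 ug/mL and compound 3 `CCCCCC(O)c1cc(OC)c2c(c1OC)C(=O)C=CC2=O` gives 0.066 ug/mL, both lower than compound 2 by more than the scatter. Compound 4 `CCCCC(O)C1=CC(=O)c2c(OC)ccc(OC)c2C1=O` differs from compound 2 in one place: ethyl in place of hydrogen on a saturated chain carbon, three bonds along the chain from a double-bonded ring carbon and an oxygen on a saturated carbon. For the measured compounds named here, the only measured step of the same kind is a 2.0-fold lower number from compound 1 to compound 3 (0.30 log units; within the scatter), where a longer chain on the hydroxyl-bearing carbon changed the number by little. A similarly small step is therefore expected here, estimated as a 1.5-fold lower number from compound 2 to compound 4 (0.17 log units; within the scatter). In this assay compound 4 is expected to give about 0.35 ug/mL, with a likely range from 0.15 ug/mL to 0.8 ug/mL.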

Compound 4, concentration for half-maximal effect: 0.412 ug/mL
For compound 4 the middle estimate is 1.2-fold (0.07 log units) below the measured one; the range from low to high includes it.
By their numbers in this assay, from the lowest: compounds 3 and 1 (each within the scatter of the next); then compounds 4 and 2 (each within the scatter of the next).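

The added ethyl gives a 1.3-fold lower number from compound 2 to compound 4 (0.10 log units; within the scatter) in this assay so 1-hydroxypropyl and 1-hydroxypentyl cannot be told apart at this position. A longer chain on the hydroxyl-bearing carbon now stays within the scatter on a second core, alongside a 2.0-fold lower number from compound 1 to compound 3 (0.30 log units; within the scatter) on the core of compound 1. Nothing available explains this result.

The compounds shown leave open whether a much longer chain, such as decyl, would move the number beyond the scatter. They also leave open what an amine in place of the hydroxyl would do on this carbon.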